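The source may hold more compounds than are shown below. What is called first, only, known or untested is meant among the compounds shown, and "the series" means these compounds.

Measured compounds, in a functional assay on HeLa cells (Homo sapiens) for inhibition, read by MTT assay, with a stated time of 24 h; a higher number here means a weaker inhibitor, a lower number a stronger inhibitor:
- compound 1 `CCOC(=O)C1=Cc2ccccc2OC1(OCc1cn(CC(=O)Nc2cccc(Cl)c2)nn1)C(F)(F)F`: 12300 nM
- compound 2 `CCOC(=O)C1=Cc2ccccc2OC1(OCc1cn(CC(=O)Nc2ccc(C)cc2)nn1)C(F)(F)F`: 67400 nM
- compound 3 `CCOC(=O)C1=Cc2ccccc2OC1(OCc1cc(-c2ccc(Cl)cc2)no1)C(F)(F)F`: 12300 nM

Compound 1 sits level with compound 3 at the digits given, the two together the lowest of the three numbers; compound 2 is the furthest from it, the step being a 5.5-fold higher number from compound 1 to compound 2 (0.74 log units; beyond the scatter).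

Compound 4 `CCOC(=O)C1=Cc2ccccc2OC1(OCc1cn(-c2cccc(C(F)(F)F)c2)nn1)C(F)(F)F` differs from compound 1 in one place: 3-(trifluoromethyl)phenyl in place of ((3-chlorophenyl)carbamoyl)methyl on an aromatic nitrogen

Going by the values given here, none of the measured steps tests this change directly. Among the compounds with values here, the only measured step, a 5.5-fold higher number from compound 1 to compound 2 (0.74 log units; beyond the scatter), swaps one aryl for another on the amide-type nitrogen and keeps the whole arm; here the arm is removed and an aryl is placed on the ring nitrogen itself. Compound 3, with an aryl attached directly to a different five-membered ring, gives the same number as compound 1, which is the nearest hint that a directly attached aryl is tolerated. The expectation for compound 4 is therefore a step of a 1.2-fold higher number from compound 1 to compound 4 (0.09 log units; within the scatter), within the scatter, in this assay. Compound 4 is estimated at 15000 nM, range 4000 nM to 60000 nM.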

Compound 4, half-maximal inhibitory concentration: > 150000 nM
Compound 4: a limit, no number; the forecaster's own chance of this, stated with the estimate: 10%; middle value at least 10-fold (1.00 log units) from the limit.
By their numbers in this assay, from the lowest: compounds 1 and 3 (each within the scatter of the next); then compound 2. At a limit, above all of these: compound 4.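

In this assay compound 4 carries only a limit, not a number: the limit of > 150000 nM in this assay, at which 1 of the 4 values shown sits. Replacing the carbamoylmethyl arm on the aromatic nitrogen with 3-(trifluoromethyl)phenyl gives an at least 12-fold higher number from compound 1 to compound 4 (1.08 log units; beyond the scatter), and the matching replacement of ((4-methylphenyl)carbamoyl)methyl gives an at least 2.2-fold higher number from compound 2 to compound 4 (0.34 log units; beyond the scatter). The earlier step changed only the aryl group within the arm, whereas these two steps show that this position does not tolerate every aryl-bearing group and that exchanging the whole arm can cost more than exchanging its aryl group.

The change removes the arm and alters the aryl substituent together, so the contribution of each cannot be separated here. A 3-chlorophenyl or plain benzyl group on the same nitrogen, or a longer chain ending in a carboxylic acid, would help to separate them.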